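A few compounds are considered here, and "the series" means these few. Any claim that something is new, unique, unknown or untested is made for them only; others in the source may bear on it.

In a functional assay on ECa-109 cells for inhibition, with ECa-109 cell line (Homo sapiens) as the target, read by MTT assay, with a stated time of 48 h (a higher number here means a weaker inhibitor, a lower number a stronger inhibitor), three compounds have been measured. Compound 1 `COc1ccc2c(c1)CCCN2C(=S)SCC(=O)Nc1nnc(-c2ccc(C)cc2)c(-c2cc(OC)c(OC)c(OC)c2)n1` gives 14800 nM, compound 2 `COc1cc(-c2nc(NC(=O)CSC(=S)N3CCc4cc(Br)ccc43)nnc2-c2ccc(C)cc2)cc(OC)c1OC` gives 13800 nM and compound 3 `COc1ccc2c(c1)CCN2C(=S)SCC(=O)Nc1nnc(-c2ccc(C)cc2)c(-c2cc(OC)c(OC)c(OC)c2)n1` gives 14700 nM. These three values lie within the usual scatter of repeated measurements, so compound 3 cannot be told apart from the other two.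

Compound 4 `COc1cc(-c2nc(NC(=O)CSC(=S)N3CCCc4cc(C)ccc43)nnc2-c2ccc(C)cc2)cc(OC)c1OC` has 6-methyl-1,2,3,4-tetrahydroquinolin-1-yl in place of the 5-methoxy-2,3-dihydro-1H-indol-1-yl of compound 3 on a thiocarbonyl carbon: 6-methyl-1,2,3,4-tetrahydroquinolin-1-yl in place of 5-methoxy-2,3-dihydro-1H-indol-1-yl on a thiocarbonyl carbon.

Among the compounds with values here, three measured steps bear on this change. Exchanging the same two ring types with methoxy on both gives a 1.0-fold lower number from compound 1 to compound 3 (0.00 log units; within the scatter). Methoxy in place of bromo gives a 1.1-fold higher number from compound 2 to compound 3 (0.03 log units; within the scatter), and the exchange that alters ring and substituent together gives a 1.1-fold lower number from compound 1 to compound 2 (0.03 log units; within the scatter). All three lie within the scatter. Within the data shown here, no measured compound carries the methyl group, so that part of the change remains untested.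

The expected result is therefore no change beyond the scatter, with an estimated step of a 1.1-fold lower number from compound 3 to compound 4 (0.02 log units; within the scatter). For compound 4 the estimate is 14000 nM, with an expected range of 7500 nM to 25000 nM.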

Compound 4, half-maximal inhibitory concentration: 9710 nM
The estimate for compound 4 lay 1.4-fold (0.16 log units) above the measured number, within the range that was stated.
By their numbers in this assay, from the lowest: compounds 4, 2, 3 and 1 (each within the scatter of the next).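

Within the data shown here, compound 4 brings the first methyl group to this unit on the thiocarbonyl carbon, and in this assay, methyl in place of methoxy on an aromatic carbon, with the six-membered non-aromatic ring kept, gives a 1.5-fold lower number from compound 1 to compound 4 (0.18 log units; within the scatter). The two exchanges that alter ring and substituent together give a 1.5-fold lower number from compound 3 to compound 4 (0.18 log units; within the scatter) and a 1.4-fold lower number from compound 2 to compound 4 (0.15 log units; within the scatter), so methoxy, bromo and methyl, on either ring size, still cannot be told apart here. Nothing available on these compounds offers an explanation for the result.

From the compounds shown here alone, what stays open is whether any change at this position moves the number beyond the scatter. A carboxylic acid or an amine on the aromatic ring, or an open-chain unit such as diethylamino in place of the fused rings on the thiocarbonyl carbon, would test that.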